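The compounds below may be only part of what the source reports. "The series", "measured", "known", "first", "only" and "open" are said of these compounds alone.

Compound 1: `O=[N+]([O-])c1ccc(N/C(=N\O)c2ccccc2Cl)c2nonc12` — in an assay on isolated protein for inhibition of Indoleamine 2,3-dioxygenase 1 (Homo sapiens), read by spectrophotometry, with a stated time of 1 h (a higher number here means a weaker inhibitor, a lower number a stronger inhibitor), compound 1 gives 135 nM
Compound 2: `Cc1ccc(/C(=N/O)Nc2ccc([N+](=O)[O-])c3nonc23)cc1` — in this assay compound 2 gives 204 nM

Compound 2 holds the higher of the two numbers in this assay, though the step of a 1.5-fold higher number from compound 1 to compound 2 (0.18 log units; within the scatter) lies within the scatter, so the two stand level. Compound 3 `O=[N+]([O-])c1ccc(N/C(=N\O)c2ccc(F)c(Cl)c2)c2nonc12` differs from compound 2 by 3-chloro-4-fluorophenyl in place of 4-methylphenyl on a carbon with a double bond to nitrogen. Within the data shown here, only one measured step bears on this, a 1.5-fold higher number from compound 1 to compound 2 (0.18 log units; within the scatter), which exchanged one aryl group for another at the same carbon and moved nothing beyond the scatter. Compound 3 is therefore expected to give 170 nM (range 70 nM to 420 nM) in this assay. The step of a 1.2-fold lower number from compound 2 to compound 3 (0.08 log units; within the scatter) is expected to stay within the scatter.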

Compound 3, half-maximal inhibitory concentration: 158 nM
The estimate for compound 3 lay 1.1-fold (0.03 log units) above the measured number; the measured number falls inside the stated range.
By their numbers in this assay, from the lowest: compounds 1, 3 and 2 (each within the scatter of the next).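

In this assay, placing 3-chloro-4-fluorophenyl on the carbon with a double bond to nitrogen gives a 1.3-fold lower number from compound 2 to compound 3 (0.11 log units; within the scatter) and a 1.2-fold higher number from compound 1 to compound 3 (0.07 log units; within the scatter), so both steps stay within the scatter. Three differently substituted phenyl groups now stand level at this position, whether they carry a methyl, one chlorine, or a chlorine and a fluorine. Nothing available explains this levelness.

From the compounds shown here alone, whether the position stays this level for a group other than a substituted phenyl, such as an amine, a carboxylic acid or a longer alkyl chain, remains open.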